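From chloro to trifluoromethyl on the shared core

This account rests on a few compounds, and the source may have more. Where it says the series, first, only, none or still open, it means among the compounds named here.

Compound 1 `CC(=O)N1CCN(c2cc(-c3cc(Cl)c4c(N)ncnn34)ccc2C(F)(F)F)C(=O)C1(C)C`: 87%
Compound 2 `CC(=O)N1CCN(c2cc(-c3cc(Cl)c4c(N)ncnn34)ccc2C(C)O)C(=O)C1(C)C`: 100%

Both numbers come from an ADME assay on microsomes from liver (Rattus norvegicus) for metabolic stability, read by LC-MS, using NADPH, with stated times of 6 min and 10 min, tested at 0.5 uM; a higher number here means that more of the compound is left, a lower number that less of the compound is left. For the measured compounds named here, compound 1 holds the lower of the two numbers, and the one measured step is a number 13 percentage points higher from compound 1 to compound 2 (beyond the scatter). Compound 3 `CC(=O)N1CCN(c2cc(-c3cc(C(F)(F)F)c4c(N)ncnn34)ccc2C(F)(F)F)C(=O)C1(C)C` has not been measured yet. It keeps the rest of compound 1 and differs in one place: trifluoromethyl in place of chloro on an aromatic carbon. This is trifluoromethyl in place of chloro, on an aromatic carbon of a five-membered aromatic ring with 1 nitrogen. The measured step, a modest one, swapped a different group, the trifluoromethyl on an aromatic carbon of compound 1, for 1-hydroxyethyl. Going by the values given here, no step at the chloro position has been measured, so that step gives only weak guidance. In this assay, no step beyond the scatter is expected. The expected change is a number 2 percentage points lower from compound 1 to compound 3 (within the scatter). For compound 3 the estimate is 85%, with an expected range from 70% to 97%.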

Compound 3, percent of the compound remaining: 77%
Compound 3: the middle estimate sits 8 percentage points above what was measured; the measured number falls inside the stated range.
By their numbers in this assay, from the lowest: compounds 3 and 1 (each within the scatter of the next); then compound 2.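

In this assay, trifluoromethyl in place of chloro on an aromatic carbon gives a number 10 percentage points lower from compound 1 to compound 3 (within the scatter) and so stays inside the usual spread of repeat measurements. For the compounds shown here, the earlier step changed a different place, so this is the first reading at this position on the five-membered aromatic ring: chloro, with 1 heavy atom, gives way to trifluoromethyl, with 4 heavy atoms, and no step beyond the scatter appears. Nothing measured here accounts for this outcome.

On these data alone, it remains open whether a group of another kind at this position, such as an amine or a carboxylic acid, would produce a step beyond the scatter. Also open, as far as these compounds go, is how 1-hydroxyethyl, the group carried by compound 2, would behave alongside trifluoromethyl at this position.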